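Benzyl for methyl on a cytotoxicity-inactive dioxole core

A few compounds are considered here, and "the series" means these few. Any claim that something is new, unique, unknown or untested is made for them only; others in the source may bear on it.

Working notes on a small series of cyclic ketones tested in a functional assay on HeLa cells (Homo sapiens) for cytotoxicity, read by WST assay, with a stated time of 48 h; a lower number here means a stronger inhibitor, a higher number a weaker inhibitor. Compound 1 `Cc1cc2c(c(=O)[nH]1)OC(C(=O)CC(C)C)O2` carries a methyl group on its fused core. In this assay compound 1 gives only a limit of the assay, > 100000 nM, and no number. Compound 2 `CC(C)CC(=O)[C@@H]1O[C@@]12C(=O)C=C(Cc1ccccc1)NC2=O`, a rearranged relative bearing a benzyl group, is the other compound measured. In this assay compound 2 likewise gives only a limit, > 100000 nM. Among the compounds with values here, both values therefore sit at the limit of > 100000 nM in this assay, at which 2 of the 2 values shown sit, and no step between measured compounds can be computed.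

Compound 3 `CC(C)CC(=O)C1Oc2cc(Cc3ccccc3)[nH]c(=O)c2O1` is not yet measured. It differs from compound 1 by phenyl in place of hydrogen on a saturated chain carbon bound to an aromatic carbon. Since compound 1 stands at the limit and compound 2, which already carries the benzyl group on a related core, also stands at the limit, no step beyond the scatter is expected in this assay in either direction. Compound 3 is therefore expected to remain at or near the limit, estimated at 100000 nM with a range of 30000 nM to 300000 nM, which means an expected step of a number no higher from compound 1 to compound 3 (the limit leaves the size open).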

Compound 3, half-maximal inhibitory concentration: > 100000 nM
Compound 3 gave a limit, no number; the forecaster's own chance of this, stated with the estimate: 80%; the middle value sits exactly at the limit.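

No step from compound 1 to compound 3 can be read in this assay, because both compounds stand at a limit of the assay and neither gives a number: the limit of > 100000 nM in this assay, at which 3 of the 3 values shown sit.

The compounds shown leave open whether phenyl in place of hydrogen at this place has any effect on cytotoxicity, and which structure in this series would give a readable value.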